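The source may report more compounds than this note shows. Statements on the series, on what has been measured and on what is new or still open speak of the compounds shown alone.

Three compounds of this series have numbers in an assay on Jurkat E6.1 cells for inhibition of histone deacetylase 4 (Homo sapiens), read by fluorescence; on this read-out lower numbers stand for stronger inhibition and higher numbers for weaker inhibition. Compound 1 `CC(C)(CN1CCCC1)NC(=O)c1ccc(-c2noc(C(F)(F)F)n2)cc1` gives 310 nM. Compound 3 `C[C@H](CN1CCCC(C)(C)C1)NC(=O)c1ccc(-c2noc(C(F)(F)F)n2)cc1` gives 10 nM. Compound 2 `CCCN(CCC)C[C@@H](C)NC(=O)c1ccc(-c2noc(C(F)F)n2)cc1` gives 19000 nM, the highest of the three, with compound 1 the nearest of the others and compound 3 the furthest; both gaps lie beyond the scatter. Compound 4 `CCCN(CCC)C[C@@H](C)NC(=O)c1ccc(-c2noc(C)n2)cc1` has not yet been measured in this assay. Its change from compound 2 is methyl in place of difluoromethyl on an aromatic carbon. Within the data shown here, no measured pair shows this change, so its size has to be judged from the structures alone. The change is expected to move the number upward, most likely beyond the scatter: a 2.6-fold higher number from compound 2 to compound 4 (0.42 log units; beyond the scatter). Compound 4 is therefore estimated at 50000 nM, within a range from 15000 nM to 150000 nM, and a limit rather than a number is a real possibility.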

Compound 4, half-maximal inhibitory concentration: > 50000 nM
Compound 4: no number, only a limit; the forecaster's own chance of this, stated with the estimate: 40%; the middle value sits exactly at the limit.
By their numbers in this assay, from the lowest: compound 3; then compound 1; then compound 2. At a limit, above all of these: compound 4.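

In this assay compound 4 gives > 50000 nM, which is a limit of the assay and not a number. Among these compounds, this is the first single change read at this position: with the rest of the structure held, methyl in place of difluoromethyl gives an at least 2.6-fold higher number from compound 2 to compound 4 (0.42 log units; beyond the scatter). The step has a lower bound only, so its full size stays unknown: the limit of > 50000 nM in this assay, at which 1 of the 4 values shown sits.

Where ethyl or monofluoromethyl at this position would fall remains open. Also open, as far as these compounds go, is whether methyl in place of trifluoromethyl would give a similar step on the side chains of compound 1 and compound 3.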